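Compound 3 to compound 4: methoxy in place of bromo

The source may report more compounds than this note shows. Statements on the series, on what has been measured and on what is new or still open speak of the compounds shown alone.

In a functional assay on MCF7 cells (Homo sapiens) for antiproliferative activity, read by sulforhodamine B assay, with a stated time of 48 h (a lower number here means a stronger inhibitor, a higher number a weaker inhibitor), compound 1 `COc1ccc(/C=C/C(=O)C(=Cc2ccc(O)c(OC)c2)C(=O)/C=C/c2ccc(OC)cc2OC)c(OC)c1` gives 2140 nM, compound 2 `COc1ccc(/C=C/C(=O)C(=Cc2ccc(O)c(F)c2)C(=O)/C=C/c2ccc(OC)cc2OC)c(OC)c1` gives 5450 nM and compound 3 `COc1ccc(/C=C/C(=O)C(=Cc2cc(Br)c(O)c(OC)c2)C(=O)/C=C/c2ccc(OC)cc2OC)c(OC)c1` gives 2600 nM. Compound 3 therefore has one close neighbour and one more distant neighbour on these numbers. The close pair is a 1.2-fold higher number from compound 1 to compound 3 (0.08 log units; within the scatter), and the distant pair is a 2.1-fold lower number from compound 2 to compound 3 (0.32 log units; beyond the scatter).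

Compound 4 `COc1ccc(/C=C/C(=O)C(=Cc2cc(OC)c(O)c(OC)c2)C(=O)/C=C/c2ccc(OC)cc2OC)c(OC)c1` carries methoxy in place of bromo on an aromatic carbon, ortho to a hydroxy group, which turns 3-bromo-4-hydroxy-5-methoxyphenyl into 4-hydroxy-3,5-dimethoxyphenyl: methoxy in place of bromo on an aromatic carbon.

Going by the values given here, no measured step swaps these two groups directly. The nearest evidence is a 1.2-fold higher number from compound 1 to compound 3 (0.08 log units; within the scatter), bromo in place of hydrogen, and a 2.5-fold higher number from compound 1 to compound 2 (0.41 log units; beyond the scatter), fluoro in place of methoxy on an aromatic carbon. Neither step is large, so no step beyond the scatter is expected in this assay. The estimated step is a 1.2-fold lower number from compound 3 to compound 4 (0.07 log units; within the scatter). The expected value for compound 4 is 2200 nM, with an estimated range of 1000 nM to 4800 nM.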

Compound 4, half-maximal inhibitory concentration: 970 nM
Estimate against measurement, compound 4: 2.3-fold (0.36 log units) above; the measured number lies below the stated range.
By their numbers in this assay, from the lowest: compound 4; then compounds 1 and 3 (each within the scatter of the next); then compound 2.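

In this assay this position, ortho to a hydroxy group, proves sensitive to which group it carries: methoxy in place of bromo gives a 2.7-fold lower number from compound 3 to compound 4 (0.43 log units; beyond the scatter) and methoxy in place of hydrogen gives a 2.2-fold lower number from compound 1 to compound 4 (0.34 log units; beyond the scatter), whereas bromo in place of hydrogen had stayed within the scatter. With a 5.6-fold lower number from compound 2 to compound 4 (0.75 log units; beyond the scatter) against the 3-fluoro-4-hydroxyphenyl compound as well, compound 4 has steps beyond the scatter to all three others and carries the lowest number of the series, so the 4-hydroxy-3,5-dimethoxyphenyl group is the best of those shown here. No measurement available here bears on the reason for these steps.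

The compounds shown leave open whether the lower number is particular to methoxy or would also appear with an amine, a carboxylic acid or a longer chain such as ethoxy at this position. They also leave open whether the step from methoxy holds when the neighbouring hydroxy group is replaced by a methoxy group.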